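Half a Step Back Toward the Bis(cyclopropylmethyl)amide

The compounds below may be only part of what the source reports. "The series", "measured", "known", "first", "only" and "open" are said of these compounds alone.

Compound 3 `CN(C)C(=O)c1cccc(-c2cccc(-n3ncc(C(=O)O)c3C3CC3)c2)c1F` gives 1300 nM in an assay on BEAS-2B cells for activation of nuclear factor erythroid 2-related factor 2 (Homo sapiens), read by MTT assay, with a stated time of 48 h (on this read-out lower numbers stand for an effect already at smaller amounts and higher numbers for an effect only at larger amounts of compound), the lowest of the three numbers. Compound 1 `O=C(O)c1cnn(-c2cccc(-c3cccc(C(=O)N(CC4CC4)CC4CC4)c3F)c2)c1C1CC1` gives 3500 nM and compound 2 `O=C(O)c1cnn(-c2cccc(-c3cccc(C(=O)N4CCCC5(CCCC5)C4)c3F)c2)c1C1CC1` gives 3700 nM; the steps of a 2.7-fold lower number from compound 1 to compound 3 (0.43 log units; beyond the scatter) and a 2.8-fold lower number from compound 2 to compound 3 (0.45 log units; beyond the scatter) show that the dimethylamino compound sits below both other amides, while a 1.1-fold higher number from compound 1 to compound 2 (0.02 log units; within the scatter) lies within the scatter. Compound 4 `CN(CC1CC1)C(=O)c1cccc(-c2cccc(-n3ncc(C(=O)O)c3C3CC3)c2)c1F` carries cyclopropyl in place of hydrogen on a saturated chain carbon bound to an amide-type nitrogen, so it holds one of the two cyclopropylmethyl groups of compound 1. Compound 1 sits at 3500 nM and compound 3 at 1300 nM, and compound 4 should land between them. Compound 4 is therefore expected to show a modest rise, a 1.6-fold higher number from compound 3 to compound 4 (0.21 log units; within the scatter), near the edge of the scatter. Compound 4 is estimated at 2100 nM, with a range from 1000 nM to 4200 nM.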

Compound 4, half-maximal effective concentration in the nuclear factor erythroid 2-related factor 2 assay: 2200 nM
Compound 4: the middle estimate sits 1.0-fold (0.02 log units) below what was measured; measured number inside the range.
By their numbers in the nuclear factor erythroid 2-related factor 2 assay, from the lowest: compounds 3, 4, 1 and 2 (each within the scatter of the next, the first and the last beyond it).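

Within the data shown here, in the nuclear factor erythroid 2-related factor 2 assay, cyclopropyl on this saturated chain carbon gives no step that can be read: a 1.7-fold higher number from compound 3 to compound 4 (0.23 log units; within the scatter). Compound 4 also stays within the scatter of both larger amides, with a 1.6-fold lower number from compound 1 to compound 4 (0.20 log units; within the scatter) and a 1.7-fold lower number from compound 2 to compound 4 (0.23 log units; within the scatter), so the gaps that separated compound 3 from those amides are not resolved at this intermediate. In a physicochemical assay for lipophilicity, read by HPLC, at pH 2 (on this read-out higher numbers stand for higher lipophilicity and lower numbers for lower lipophilicity), compound 3 gives 1.3 and compound 4 gives 2.2, so the same change does carry this read-out beyond the scatter.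

As far as these compounds go, whether a longer chain, or a chain ending in a hydroxyl group or an amine, would separate clearly from compound 3 in the nuclear factor erythroid 2-related factor 2 assay remains open.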